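Swapping fluoro for chloro in a bromo sulfonamide

This account rests on a few compounds, and the source may have more. Where it says the series, first, only, none or still open, it means among the compounds named here.

- Compound 1 `O=S(=O)(NCCCNc1nccc(-c2[nH]c(-c3ccccc3)nc2-c2ccc(F)c(O)c2)n1)c1ccccc1`: 9580 nM
- Compound 2 `O=S(=O)(NCCCNc1nccc(-c2[nH]c(-c3ccccc3)nc2-c2ccc(F)c(O)c2)n1)c1ccc(Br)cc1`: 5660 nM
- Compound 3 `COc1ccc(S(=O)(=O)NCCCNc2nccc(-c3[nH]c(-c4ccccc4)nc3-c3ccc(F)c(O)c3)n2)cc1`: 13900 nM

These values come from a functional assay on LOX IMVI cells (Homo sapiens) for cytotoxicity, read by MTT assay, with a stated time of 24 h; on this read-out higher numbers stand for weaker inhibition and lower numbers for stronger inhibition. Compound 2 stands close to one neighbour, with a 1.7-fold lower number from compound 1 to compound 2 (0.23 log units; within the scatter), and somewhat apart from the other, with a 2.5-fold higher number from compound 2 to compound 3 (0.39 log units; beyond the scatter). Compound 4 `O=S(=O)(NCCCNc1nccc(-c2[nH]c(-c3ccccc3)nc2-c2ccc(Cl)c(O)c2)n1)c1ccc(Br)cc1` carries chloro in place of fluoro on an aromatic carbon, ortho to a hydroxy group, turning 4-fluoro-3-hydroxyphenyl into 4-chloro-3-hydroxyphenyl: chloro in place of fluoro on an aromatic carbon. Within the data shown here, no measured step touches this place. Among the measured compounds shown here, the only halogen step, at another place, is a 1.7-fold lower number from compound 1 to compound 2 (0.23 log units; within the scatter), so no change beyond the scatter is expected. The estimated change is a 1.1-fold lower number from compound 2 to compound 4 (0.05 log units; within the scatter). Compound 4 is expected at 5000 nM, with an estimated range of 2400 nM to 10500 nM.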

Compound 4, half-maximal inhibitory concentration: 15500 nM
For compound 4 the middle estimate is 3.1-fold (0.49 log units) below the measured one; the measured number lies above the stated range.
By their numbers in this assay, from the lowest: compounds 2, 1, 3 and 4 (each within the scatter of the next, the first and the last beyond it).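

Chloro in place of fluoro at this place gives a 2.7-fold higher number from compound 2 to compound 4 (0.44 log units; beyond the scatter) in this assay, so the position responds to the choice of halogen and the larger number marks weaker inhibition. Among these compounds, the earlier steps lay at another place, and this is the first to show a change here. Nothing at hand gives a reason for the shift.

On these data alone, whether the same swap acts alike with hydrogen or methoxy in place of the bromo stays open. So does how a methyl, a bromo or an amine would fare at this place.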